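The source may hold more compounds than are shown below. What is called first, only, known or untested is meant among the compounds shown, and "the series" means these compounds.

Compound 1 `COc1ccccc1NC(=S)N/N=C/c1ccc2ccccc2n1`: > 100000 nM in a functional assay on HeLa cells (Homo sapiens) for antiproliferative activity, read by sulforhodamine B assay, with a stated time of 72 h; a lower number here means a stronger inhibitor, a higher number a weaker inhibitor
Compound 2 `CN(C)C(=S)N/N=C/c1ccc2ccccc2n1`: 90 nM
Compound 3 `CN(C)C(=S)N/N=C/c1cnc2ccccc2n1`: 750 nM

The value of compound 1 is a limit of this assay, not a number; compound 1 sits at the limit of > 100000 nM in this assay, at which 1 of the 3 values shown sits, so all that is known is that it lies at the weak end of the range this assay can report. Compound 2 and compound 3 carry a dimethyl group on the amide-type nitrogen instead of an aryl group and differ from each other in their core; in this assay compound 2 gives 90 nM and compound 3 gives 750 nM, both well inside the measurable range.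

Compound 4 `S=C(N/N=C/c1ccc2ccccc2n1)Nc1ccc(Cl)cc1` differs from compound 1 in one place: 4-chlorophenyl in place of 2-methoxyphenyl on an amide-type nitrogen. Within the data shown here, no measured pair differs only in this way, so the size of the step is open. Since compound 1 rests at the limit of > 100000 nM in this assay, at which 1 of the 3 values shown sits, the only direction in which a number can appear for compound 4 is toward lower values in this assay; the step from compound 1 to compound 4 is therefore expected to be downward, an at least 12-fold lower number from compound 1 to compound 4 (1.09 log units; beyond the scatter), though whether compound 4 reaches the measurable range at all is uncertain. Compound 4 is expected to give about 8000 nM, with a range from 400 nM to 100000 nM.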

Compound 4, half-maximal inhibitory concentration: > 100000 nM
Compound 4 ended at the assay's limit (the forecaster's own chance of this, stated with the estimate: 35%); middle value at least 12-fold (1.09 log units) from the limit.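

In this assay compound 4 gives > 100000 nM, which is a limit of the assay and not a number. Compound 1 also rests at a limit, so no step can be read between compound 1 and compound 4: the limit of > 100000 nM in this assay, at which 2 of the 4 values shown sit.

The compounds shown leave open how much 4-chlorophenyl and 2-methoxyphenyl differ on that nitrogen, and whether any aryl group there gives a measurable value.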